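Trading an Ester Side Chain for a Dimethylamino Group

A few compounds are considered here, and "the series" means these few. Any claim that something is new, unique, unknown or untested is made for them only; others in the source may bear on it.

In a functional assay on HeLa cells (Homo sapiens) for cytotoxicity, read by neutral red uptake, with a stated time of 3 days (on this read-out lower numbers stand for stronger inhibition and higher numbers for weaker inhibition), compound 1 `[N-]=[N+]=Nc1c(F)c(N)c2c(=O)cc(-c3ccc(N)c(F)c3)oc2c1F` gives 1200 nM, compound 2 `Nc1ccc(-c2cc(=O)c3c(N)c(F)c(N)c(F)c3o2)cc1F` gives 19000 nM, and compound 3 `CCCCCC(=O)OCc1c(F)c(N)c2c(=O)cc(-c3ccc(N)c(F)c3)oc2c1F` gives 34000 nM, the highest of the three numbers, though its gap from compound 2 lies within the scatter. That gap is a 1.8-fold higher number from compound 2 to compound 3 (0.25 log units; within the scatter), whereas the steps away from compound 1 are a 16-fold higher number from compound 1 to compound 2 (1.20 log units; beyond the scatter) and a 28-fold higher number from compound 1 to compound 3 (1.45 log units; beyond the scatter). Compound 4 `CN(C)Cc1c(F)c(N)c2c(=O)cc(-c3ccc(N)c(F)c3)oc2c1F` differs from compound 3 by dimethylamino in place of (pentylcarbonyl)oxy on a saturated chain carbon bound to an aromatic carbon. Among the measured compounds shown here, no measured step touches this saturated chain carbon, so the only guide is that compound 2 and compound 3 sit together, far from compound 1. On that basis the expected step is a 1.4-fold lower number from compound 3 to compound 4 (0.13 log units; within the scatter), not beyond the scatter. Compound 4 is therefore estimated at 25000 nM, within 8000 nM to 80000 nM.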

Compound 4, half-maximal inhibitory concentration: 8900 nM
Compound 4: the middle estimate sits 2.8-fold (0.45 log units) above what was measured; measured number inside the range.
By their numbers in this assay, from the lowest: compound 1; then compound 4; then compounds 2 and 3 (each within the scatter of the next).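

At the saturated chain carbon bound to an aromatic carbon, dimethylamino in place of (pentylcarbonyl)oxy gives a 3.8-fold lower number from compound 3 to compound 4 (0.58 log units; beyond the scatter) and so shows that the read-out responds to the group carried there. The (dimethylamino)methyl group also separates from amino, with a 2.1-fold lower number from compound 2 to compound 4 (0.33 log units; beyond the scatter) on that exchange, yet it falls short of azido, with a 7.4-fold higher number from compound 1 to compound 4 (0.87 log units; beyond the scatter) on the exchange from that group. Nothing available here accounts for these steps.

On these data alone, whether a cyclic amine such as morpholine, a primary amine or a shorter ester such as an acetate would sit closer to the azido compound remains open.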